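The source may hold more compounds than are shown below. What is called first, only, known or untested is meant among the compounds shown, and "the series" means these compounds.

Measured in a functional assay on MCF7 cells (Homo sapiens) for antiproliferative activity, read by MTT assay, with a stated time of 48 h; on this read-out higher numbers stand for weaker inhibition and lower numbers for stronger inhibition:
- compound 1 `COC(=O)[C@H](C)NC(=O)c1ccc(Oc2nc3ccccc3nc2C)cc1`: 38400 nM
- compound 2 `COC(=O)[C@H](C)NC(=O)c1ccc(Oc2nc3ccccc3nc2NC(C)(C)C)cc1`: 38400 nM

Level with compound 1, the only other compound measured so far, compound 2 shows 38400 nM. Just one measured step is available: no change at the digits printed from compound 1 to compound 2 (within the scatter), with (tert-butyl)amino in place of methyl on an aromatic carbon.

The next compound is compound 3 `C[C@H](NC(=O)c1ccc(Oc2nc3ccccc3nc2NC(C)(C)C)cc1)C(=O)O`. Its difference from compound 2 is hydrogen in place of methyl on an oxygen next to a carbonyl group, which turns methoxycarbonyl into carboxy. Among the measured compounds shown here, the measured step changed a different place on the molecule, so it says nothing direct about this swap, and no measured pair shows methoxycarbonyl to carboxy. For the measured compounds named here, with no measured precedent, neither direction can be favoured, so the working expectation is no movement beyond the usual scatter in this assay, held with a wide margin. The expected change is a 1.0-fold higher number from compound 2 to compound 3 (0.02 log units; within the scatter). For compound 3 the estimated value is 40000 nM, with an expected range of 15000 nM to 100000 nM.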

Compound 3, half-maximal inhibitory concentration: 29400 nM
The estimate for compound 3 lay 1.4-fold (0.13 log units) above the measured number; measured number inside the range.
By their numbers in this assay, from the lowest: compounds 3, 1 and 2 (each within the scatter of the next).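

In this assay, the change from 1-(methoxycarbonyl)ethyl to 1-carboxyethyl, which puts hydrogen in place of methyl on an oxygen next to a carbonyl group, gives a 1.3-fold lower number from compound 2 to compound 3 (0.12 log units; within the scatter). Among the compounds shown here, the earlier step concerned a different place on the molecule, so this pair is the first to probe this group, and it shows that the methyl ester can give way to the free carboxy group without the reading leaving the usual scatter. Nothing measured alongside these compounds offers an explanation for this result.

On these data alone, this is a single pair, so it remains open whether the same swap would read the same way on the core of compound 1, which carries methyl where compound 2 carries (tert-butyl)amino. The compounds shown also leave open what would happen with a different group in place of methoxycarbonyl, such as an ethyl ester, a primary amide or a longer chain ending in a carboxylic acid.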